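A few compounds are considered here, and "the series" means these few. Any claim that something is new, unique, unknown or untested is made for them only; others in the source may bear on it.

Three compounds share one core. Compound 1, `O=C(Nc1ccc(C(F)(F)F)cc1)c1csc(-c2c(Cl)cccc2Cl)n1`, carries the 2,6-dichlorophenyl directly on the core. Its value in an assay on CHO cells, read by calcium flux (on this read-out lower numbers stand for stronger inhibition and higher numbers for weaker inhibition), is a limit of the assay, > 4000 nM (the limit of > 4000 nM in this assay, at which 1 of the 3 values shown sits). Compound 2, `O=C(Nc1ccc(C(F)(F)F)cc1)c1csc(Nc2c(Cl)cccc2Cl)n1`, has (2,6-dichlorophenyl)amino in place of 2,6-dichlorophenyl on an aromatic carbon, and in this assay compound 2 gives 48 nM. Compound 3, `O=C(Nc1ccc(C(F)(F)F)cc1)c1csc(Nc2ccccc2Cl)n1`, with hydrogen in place of chloro on an aromatic carbon, gives 1410 nM in this assay. The steps of an at least 83-fold lower number from compound 1 to compound 2 (1.92 log units; beyond the scatter) and an at least 2.8-fold lower number from compound 1 to compound 3 (0.45 log units; beyond the scatter) both run toward lower numbers; the step of a 29-fold higher number from compound 2 to compound 3 (1.47 log units; beyond the scatter) runs the other way. Compound 2 thus stands lowest of the two numbers shown, with compound 3 the nearest.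

Compound 4, `NS(=O)(=O)c1cc(Cl)c(Nc2nc(C(=O)Nc3ccc(C(F)(F)F)cc3)cs2)c(Cl)c1`, differs from compound 2 by sulfamoyl in place of hydrogen on an aromatic carbon, meta to two chloro groups and para to a large group. Within the data shown here, none of the measured steps touches this position; the step of a 29-fold higher number from compound 2 to compound 3 (1.47 log units; beyond the scatter) shows only that the dichlorinated ring responds strongly to a change elsewhere on it. Among the measured compounds shown here, with no comparable measured step, a small change is expected: compound 4 is estimated at 80 nM, between 20 nM and 320 nM. That estimate means an expected step of a 1.7-fold higher number from compound 2 to compound 4 (0.22 log units; within the scatter).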

Compound 4, half-maximal inhibitory concentration: 1740 nM
Compound 4: the middle estimate sits 22-fold (1.34 log units) below what was measured; the measured number lies above the stated range.
By their numbers in this assay, from the lowest: compound 2; then compounds 3 and 4 (each within the scatter of the next). At a limit, above all of these: compound 1.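

In this assay, the aromatic carbon meta to two chloro groups and para to a large group proves far from indifferent, which the earlier compounds could not show: sulfamoyl in place of hydrogen there gives a 36-fold higher number from compound 2 to compound 4 (1.56 log units; beyond the scatter) and is the only step shown at this carbon. Among these compounds, the ring bearing the two chloro groups therefore responds strongly not only to the loss of a chloro group, with a 29-fold higher number from compound 2 to compound 3 (1.47 log units; beyond the scatter) as the earlier large step, but also to an added group at a carbon that the earlier compounds left unchanged. Nothing given here accounts for the size of the new step.

On these data alone, it remains open whether this rise belongs to sulfamoyl specifically or would also follow a methyl group, a fluoro group, an amine or a carboxylic acid on the same carbon. As far as these compounds go, it is equally open whether a sulfamoyl group carrying methyl on its nitrogen would behave like the unsubstituted one.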